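From a Propyl Chain to a 2-Hydroxyethyl Chain

This account rests on a few compounds, and the source may have more. Where it says the series, first, only, none or still open, it means among the compounds named here.

Of the compounds shown here, three have been measured in an ADME assay on BSC-1 cells (Chlorocebus aethiops) for cytotoxicity, read by WST assay, with a stated time of 120 h; on this read-out higher numbers stand for lower toxicity in this test and lower numbers for higher toxicity in this test. Compound 1 (`O=C1/C(=C/C2CCCO2)CC/C1=C\C1CCCO1`) gives 50 uM. Compound 2 (`Cc1cc(OC(=O)c2ccco2)nc(SCc2c(Cl)cccc2Cl)n1`) reads > 100 uM, which is a limit of the assay and not a number. Compound 3 (`CCC/N=c1\cc(-c2ccccc2)oc2ccc(C)cc12`) gives 10 uM, the lower of the two actual numbers. Its nearest neighbour, compound 1, stands higher by a gap beyond the usual scatter.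

Compound 4 (`Cc1ccc2oc(-c3ccccc3)c/c(=N\CCO)c2c1`) has not yet been measured. It keeps the core of compound 3 and differs in one place: hydroxy in place of methyl on a saturated chain carbon, two bonds along the chain from a double-bonded nitrogen. This is hydroxy in place of methyl on a saturated chain carbon, two bonds along the chain from a double-bonded nitrogen, so that propyl becomes 2-hydroxyethyl.

Within the data shown here, no measured pair in this set shows what such a change does, so the expectation is a loose one. Compound 3 at 10 uM sits at the low end of the numbers seen, which leaves a rise as the likelier direction. The expected change is a 2.5-fold higher number from compound 3 to compound 4 (0.40 log units; beyond the scatter), a moderate rise estimated to lie a little beyond the scatter. For compound 4 the estimated value is 25 uM, with an expected range from 8 uM to 80 uM.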

Compound 4, half-maximal toxic concentration: 12 uM
Compound 4: middle estimate off by 2.1-fold (0.32 log units), on the high side; measured number inside the range.
By their numbers in this assay, from the lowest: compounds 3 and 4 (each within the scatter of the next); then compound 1. At a limit, above all of these: compound 2.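

In this assay the exchange of methyl for hydroxy, on a saturated chain carbon, two bonds along the chain from a double-bonded nitrogen, gives a 1.2-fold higher number from compound 3 to compound 4 (0.08 log units; within the scatter) and so leaves the two compounds within the scatter of each other. Among these compounds, this is the first direct comparison at this position, and it shows that propyl and 2-hydroxyethyl read alike here, even though the change brings one hydrogen-bond donor and one hydrogen-bond acceptor onto the chain. The information at hand bears on no cause for this result.

A single step covers only one replacement at one place on the shared core, so it cannot tell whether an amine, a carboxylic acid or a longer chain in place of the 2-hydroxyethyl chain of compound 4 would read the same. Nor can it tell whether the same exchange of methyl for hydroxy would read alike on a different core, since only this one pair carries it.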